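The source may report more compounds than this note shows. Statements on the series, on what has been measured and on what is new or still open speak of the compounds shown alone.

Compound 1 `N[C@H]1CC[C@H](Nc2nc(Nc3ccc(Oc4nccs4)cc3)c3ncn(C4CCCC4)c3n2)CC1`: 650 nM
Compound 2 `NCCCCNc1nc(Nc2ccc(Oc3nccs3)cc2)c2ncn(C3CCCC3)c2n1`: 8640 nM
Compound 3 `N[C@H]1CC[C@H](Nc2nc(Nc3ccc(N4CCN(Cc5ccccc5)CC4)cc3)c3ncn(CCCO)c3n2)CC1`: 4560 nM

These three compounds were tested in an ADME assay on CCRF-CEM cells (Homo sapiens) for inhibition, read by fluorescence and resazurin assay, with a stated time of 72 h; a higher number here means a weaker inhibitor of growth, a lower number a stronger inhibitor of growth. Compound 1 gives 650 nM and compound 2 gives 8640 nM. The change between them, (4-aminobutyl in place of 4-aminocyclohexyl on a nitrogen on an aromatic ring), produced a 13-fold higher number from compound 1 to compound 2 (1.12 log units; beyond the scatter). Compound 3, which gives 4560 nM, sits on a different core; the difference between its core and that of compound 1 is not broken down here. Compound 4 `NCCCCNc1nc(Nc2ccc(N3CCN(Cc4ccccc4)CC3)cc2)c2ncn(CCCO)c2n1` has not yet been tested. It is made from compound 3 by the same kind of change, (4-aminobutyl in place of 4-aminocyclohexyl on a nitrogen on an aromatic ring), at a place described in the same words. Among the measured compounds shown here, because of a 13-fold higher number from compound 1 to compound 2 (1.12 log units; beyond the scatter), the step from compound 3 to compound 4 is expected to be a clear weakening too, estimated at an 8.8-fold higher number from compound 3 to compound 4 (0.94 log units; beyond the scatter), though only one earlier example supports this. Compound 4 is therefore estimated to give 40000 nM in this assay, expected to lie between 12000 nM and 150000 nM.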

Compound 4, concentration for 50% growth inhibition: 7570 nM
Compound 4: the middle estimate sits 5.3-fold (0.72 log units) above what was measured; the measured number lies below the stated range.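

On the core of compound 3, the change gives a 1.7-fold higher number from compound 3 to compound 4 (0.22 log units; within the scatter), so in this assay this step cannot be told apart from no change at all. The change therefore does not keep a fixed size from one core to another in this series, and the two examples clearly disagree: the same change on two cores in this assay, a 13-fold higher number (1.12 log units; beyond the scatter) from compound 1 to compound 2 and a 1.7-fold higher number (0.22 log units; within the scatter) from compound 3 to compound 4, 8.0-fold (0.90 log units) apart, beyond the scatter of two such steps

Two pairs do not show why the steps differ, nor how the change would behave on a third core. Still open, on these data alone, is which difference between the two cores sets the size of the step. Also open, as far as these compounds go, is how a shorter chain such as 3-aminopropyl, or a 4-hydroxybutyl group with a hydroxyl in place of the amine, would behave on each core.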